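Swapping chloro for trifluoromethyl: what to expect of compound 4

A few compounds are considered here, and "the series" means these few. Any claim that something is new, unique, unknown or untested is made for them only; others in the source may bear on it.

Compound 1 `COc1cc2oc(-c3cccc(NC(=O)c4cccc(Br)c4)c3)cc(=O)c2c(OC)c1OC` gives 6340 nM
Compound 2 `COc1cc2oc(-c3cccc(NC(=O)c4ccc(Cl)cc4)c3)cc(=O)c2c(OC)c1OC` gives 8780 nM
Compound 3 `COc1cc2oc(-c3cccc(NC(=O)c4ccc(F)cc4)c3)cc(=O)c2c(OC)c1OC` gives 14700 nM

These three compounds share one core and differ only in the substituted ring on the carbonyl carbon. All three numbers come from a functional assay on MCF7 cells (Homo sapiens) for inhibition, read by MTT assay (a lower number here means a stronger inhibitor of growth, a higher number a weaker inhibitor of growth), and compound 2 sits in the middle of them. Its steps to the other two stay within the scatter (a 1.4-fold higher number from compound 1 to compound 2 (0.14 log units; within the scatter)) (a 1.7-fold higher number from compound 2 to compound 3 (0.22 log units; within the scatter)), so those gaps cannot be read as real differences. Only the gap between the outer two compounds goes beyond the scatter, and it is modest (a 2.3-fold higher number from compound 1 to compound 3 (0.37 log units; beyond the scatter)).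

Compound 4 `COc1cc2oc(-c3cccc(NC(=O)c4ccc(C(F)(F)F)cc4)c3)cc(=O)c2c(OC)c1OC` has not been measured yet. It keeps everything in compound 2 except one group, with trifluoromethyl in place of chloro on an aromatic carbon. The closest guide is the swap of chloro for fluoro at that same place, the step to compound 3 shown above, which stayed within the scatter. Going by the values given here, no measured compound carries trifluoromethyl, so this guide is only a loose one. Across the series, all steps are small.

The step expected in this assay is therefore none beyond the scatter (a 1.0-fold higher number from compound 2 to compound 4 (0.01 log units; within the scatter)), with no direction favoured. For compound 4 the estimated value is 9000 nM, with an expected range from 4000 nM to 20000 nM.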

Compound 4, concentration for 50% growth inhibition: 10600 nM
For compound 4 the middle estimate is 1.2-fold (0.07 log units) below the measured one; the range from low to high includes it.
By their numbers in this assay, from the lowest: compounds 1, 2, 4 and 3 (each within the scatter of the next, the first and the last beyond it).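

In this assay, putting trifluoromethyl, with its four heavy atoms, in place of the single chlorine on the aromatic carbon para to a large group gives a step within the scatter (a 1.2-fold higher number from compound 2 to compound 4 (0.08 log units; within the scatter)), and the swap from fluoro is also within the scatter (a 1.4-fold lower number from compound 3 to compound 4 (0.14 log units; within the scatter)). Fluoro, chloro and trifluoromethyl at this place therefore cannot be told apart in this assay, and compound 4 also stays within the scatter of the 3-bromophenyl compound (a 1.7-fold higher number from compound 1 to compound 4 (0.22 log units; within the scatter)), leaving (a 2.3-fold higher number from compound 1 to compound 3 (0.37 log units; beyond the scatter)) as the only step shown beyond the scatter. No measurement is available that could explain why these groups give such similar numbers.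

The compounds shown leave open whether a different kind of group at this place, such as an amine, a carboxylic acid or a longer chain, would produce a step beyond the scatter. They also leave open whether a change on the shared core would do more than these swaps on the ring attached to the carbonyl.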